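Phenyl for thiophen-3-yl on the shared core: cytotoxicity notes

The compounds below may be only part of what the source reports. "The series", "measured", "known", "first", "only" and "open" are said of these compounds alone.

Compound 1 `Nc1nc(N)c2c(-c3ccsc3)cn([C@@H]3O[C@H](CO)[C@@H](O)[C@H]3O)c2n1` is read in an ADME assay on BJ cells (Homo sapiens), read by MTT assay, with a stated time of 72 h; on this read-out lower numbers stand for stronger inhibition and higher numbers for weaker inhibition. In this assay compound 1 reaches only the assay limit, reported as > 100000 nM. Compound 2 `O=c1[nH]cnc2c1c(-c1cccs1)cn2[C@@H]1O[C@H](CO)[C@@H](O)[C@H]1O` likewise sits at the limit, reported as > 100000 nM. Compound 3 `Cc1ncnc2c1c(-c1ccoc1)cn2[C@@H]1O[C@H](CO)[C@@H](O)[C@H]1O` gives a number, 89200 nM. For the measured compounds named here, compound 1 thus stands at the limit rather than on a value, a position shared within the set (the limit of > 100000 nM in this assay, at which 2 of the 3 values shown sit); no measured step between neighbours is available. Compound 4 `Nc1nc(N)c2c(-c3ccccc3)cn([C@@H]3O[C@H](CO)[C@@H](O)[C@H]3O)c2n1` differs from compound 1 by phenyl in place of thiophen-3-yl on an aromatic carbon. With compound 1 at the limit, the step is expected to be none beyond the scatter, a number no higher from compound 1 to compound 4 (the limit leaves the size open), most likely ending again at the limit. Compound 4 is therefore estimated at 100000 nM, with a range from 30000 nM to 300000 nM.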

Compound 4, half-maximal inhibitory concentration: > 100000 nM
Compound 4 was reported as a limit (the forecaster's own chance of this, stated with the estimate: 80%); the middle value sits exactly at the limit.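

No step can be read from compound 1 to compound 4, phenyl in place of thiophen-3-yl, since both stand at a limit: the limit of > 100000 nM in this assay, at which 3 of the 4 values shown sit.

The compounds shown leave open whether this exchange changes the read-out at all.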